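Chloro for Nitro on a Weakly Active Amide Pair

The source may report more compounds than this note shows. Statements on the series, on what has been measured and on what is new or still open speak of the compounds shown alone.

Compound 1 `Nc1ccccc1NC(=O)c1ccc(CSC(=S)N2CCc3cc([N+](=O)[O-])ccc32)cc1`: 16.9%
Compound 2 `Nc1ccccc1NC(=O)c1ccc(CSC(=S)N2CCN(c3ccc(F)cc3)CC2)cc1`: 20.9%

Both measured compounds share a core and a thiocarbamate-linked tail, and both act only weakly. In a functional assay on A-375 cells (Homo sapiens) for antiproliferative activity, read by CCK-8 assay, with a stated time of 72 h, tested at 2 uM (a lower number here means a weaker effect, a higher number a stronger effect of the compound at the concentration tested), compound 1 gives 16.9%. Compound 2 gives 20.9% in this assay, a number within the usual scatter of compound 1's, so the two cannot be set apart and neither can be called stronger or weaker.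

Compound 3 `Nc1ccccc1NC(=O)c1ccc(CSC(=S)N2CCc3cc(Cl)ccc32)cc1` differs from compound 1 in a single place: chloro in place of nitro on an aromatic carbon. Among the measured compounds shown here, no measured pair shows what such a change does here, so nothing in the data points to a direction. Given how weak compound 1 is, the step of a number 3.1 percentage points higher from compound 1 to compound 3 (within the scatter) is expected to stay small, with no change beyond the scatter in either direction. Compound 3 is therefore estimated at about 20%, most likely between 8% and 36%.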

Compound 3, a percentage reported as inhibition, at one concentration (the size of the read-out at that concentration, not a potency): 31.9%
Compound 3: the middle estimate sits 11.9 percentage points below what was measured; low and high end bracket the measured number.
By their numbers in this assay, from the lowest: compounds 1 and 2 (each within the scatter of the next); then compound 3.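

In this assay, chloro in place of nitro on this aromatic carbon gives a number 15 percentage points higher from compound 1 to compound 3 (beyond the scatter). Among the compounds shown here, this is the first change that moves the read-out past the usual scatter, so this place on the ring is not indifferent to what sits there, even though the effect of compound 3 at the tested concentration remains partial. No measurement shown explains why the swap has this effect.

A single pair cannot tell whether losing the nitro or adding the chloro matters more, and a plain hydrogen, a fluoro, a methoxy or an amine on the same carbon would help separate the two. Going by these compounds, it also remains open whether the same swap would have a similar effect on a different core.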